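This account rests on a few compounds, and the source may have more. Where it says the series, first, only, none or still open, it means among the compounds named here.

Compound 1 `COc1ccc(C(/C=C/c2ccc(Cl)cc2)=N/O)cc1` gives 291000 nM in an ADME assay on cells (Mus musculus, strain Balb/c) for cytotoxicity, read by MTT assay, with a stated time of 48 h; on this read-out higher numbers stand for lower toxicity in this test and lower numbers for higher toxicity in this test. Compound 3 `O/N=C(\C=C\c1ccc(Cl)cc1)c1ccc(Cl)cc1` carries chloro in place of methoxy on an aromatic carbon, and in this assay compound 3 gives 14100 nM, which is a 21-fold lower number from compound 1 to compound 3 (1.31 log units; beyond the scatter). Compound 2 `COc1ccc(C(/C=C/c2cccs2)=N/O)cc1` rests on another core, and the difference between the two cores is not broken down here; in this assay compound 2 gives 10600 nM, a number within the scatter of that of compound 3 and far beyond the scatter from that of compound 1. Compound 4 `O/N=C(\C=C\c1cccs1)c1ccc(Cl)cc1` is not yet measured and carries chloro in place of methoxy on an aromatic carbon, the same change as that from compound 1 to compound 3. The step is expected to be a 3.5-fold lower number from compound 2 to compound 4 (0.55 log units; beyond the scatter), smaller than the earlier one, since compound 2 already starts from 10600 nM. Compound 4 is therefore estimated at 3000 nM, between 500 nM and 15000 nM.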

Compound 4, half-maximal cytotoxic concentration: 11800 nM
Beside the measured number, compound 4's estimate is 3.9-fold (0.59 log units) below it; the measured number falls inside the stated range.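

On the core of compound 2, chloro in place of methoxy on an aromatic carbon gives a 1.1-fold higher number from compound 2 to compound 4 (0.05 log units; within the scatter) in this assay, so this pair shows no change beyond the scatter. The size of the step therefore does not carry over between the two cores: the same change on two cores in this assay, a 21-fold lower number (1.31 log units; beyond the scatter) from compound 1 to compound 3 and a 1.1-fold higher number (0.05 log units; within the scatter) from compound 2 to compound 4, 23-fold (1.36 log units) apart, beyond the scatter of two such steps

This shows that the large step on the core of compound 1 cannot be assumed on the core of compound 2, but it does not show why the cores differ, and two pairs give no rule for any other core. The compounds shown leave open how an amine, a carboxylic acid or a longer chain would read at this same place. They also leave open whether either of those groups would behave alike on both cores.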